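Replacing the aryl ether by chloro on the shared core

This account rests on a few compounds, and the source may have more. Where it says the series, first, only, none or still open, it means among the compounds named here.

Of the compounds shown here, three sharing one core have been tested in a functional assay on Huh-7 cells (Homo sapiens) for inhibition, read by MTT assay, with a stated time of 48 h; on this read-out lower numbers stand for stronger inhibition and higher numbers for weaker inhibition. Compound 1 `Cc1nnsc1CO/N=C/c1c(C)nn(C)c1Oc1ccccc1Cl` carries a 2-chlorophenyl on the ether oxygen. In this assay compound 1 reaches only the assay limit of > 50000 nM. Compound 2 `Cc1nnsc1CO/N=C/c1c(C)nn(C)c1Oc1ccc(F)cc1` carries a 4-fluorophenyl in that place, and in this assay compound 2 likewise gives only the limit of > 50000 nM. Compound 3 `Cc1nnsc1CO/N=C/c1c(C)nn(C)c1Oc1ccc(I)cc1` carries a 4-iodophenyl there; in this assay compound 3 again reports only the limit of > 50000 nM. Compound 3 therefore stands where every value shown stands, namely at the limit of > 50000 nM in this assay, at which 3 of the 3 values shown sit. The steps a step that the two limits leave unreadable from compound 1 to compound 2, a step that the two limits leave unreadable from compound 1 to compound 3 and a step that the two limits leave unreadable from compound 2 to compound 3 cannot be read.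

Compound 4 `Cc1nnsc1CO/N=C/c1c(C)nn(C)c1Cl` has not been measured. From compound 3 it differs by chloro in place of 4-iodophenoxy on an aromatic carbon. Within the data shown here, no measured step touches this change, since all three measured steps exchange one aryl ether for another and none removes the ether. The expected step that the limit leaves unreadable from compound 3 to compound 4 is therefore set to none beyond the scatter. Compound 4 is expected in this assay at 60000 nM, within 10000 nM to 300000 nM, most likely again as a limit.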

Compound 4, half-maximal inhibitory concentration: > 50000 nM
Compound 4 was reported as a limit (the forecaster's own chance of this, stated with the estimate: 80%); the middle value lies beyond the limit too.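

In this assay compound 4 gives > 50000 nM, which is a limit. Among these compounds, no step from compound 1, compound 2 or compound 3 to compound 4 can be read, since all values coincide: the limit of > 50000 nM in this assay, at which 4 of the 4 values shown sit. The compounds shown leave open what change to the shared core, if any, would give a measurable value in this assay.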